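Swapping the Halogen on Compound 3

The compounds below may be only part of what the source reports. "The series", "measured", "known", "first", "only" and "open" are said of these compounds alone.

Measured so far:
compound 1 `Clc1ccc2[nH]cc(SC3CCNCC3)c2c1` — 0.3 mg/kg
compound 2 `O=S(=O)(c1c[nH]c2ccc(Cl)cc12)C1CCNCC1` — 12.5 mg/kg
compound 3 `Cc1[nH]c2ccc(Cl)cc2c1SC1CCNCC1` — 0.8 mg/kg

In a functional assay on the whole organism with Mus musculus as the target, in the writhing test (a higher number here means that more compound is needed for the effect, a lower number that less compound is needed), compound 3 holds the second highest of the three numbers, with compound 1 giving the lower one and compound 2 the much higher one. Among the measured compounds shown here, the single measured step, a 2.7-fold higher number from compound 1 to compound 3 (0.43 log units; beyond the scatter), concerns a change at another site and is modest. Compound 4 `Cc1[nH]c2ccc(Br)cc2c1SC1CCNCC1` differs from compound 3 by bromo in place of chloro on an aromatic carbon. No measured pair exchanges one halogen for another, so nothing shown speaks directly to this change. The expected step in this assay is no change at the digits printed from compound 3 to compound 4 (within the scatter), nothing beyond the scatter. Compound 4 is therefore estimated at 0.8 mg/kg, with a range from 0.3 mg/kg to 2 mg/kg.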

Compound 4, dose for half-maximal effect: 0.7 mg/kg
Compound 4: middle estimate off by 1.1-fold (0.06 log units), on the high side, within the range that was stated.
By their numbers in this assay, from the lowest: compound 1; then compounds 4 and 3 (each within the scatter of the next); then compound 2.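

The exchange of chloro for bromo on this aromatic carbon gives a 1.1-fold lower number from compound 3 to compound 4 (0.06 log units; within the scatter) in this assay, so the two halogens cannot be told apart in this whole-animal read-out. This is the first step shown at this position, since compounds 1, 2 and 3 all carry chloro there. Nothing available offers an explanation for this result.

The compounds shown leave open whether a halogen is needed here at all, and what a fluoro, methoxy or nitrile group would give on this carbon. They also leave open whether bromo and chloro would still match on the core of compound 1, which lacks the methyl.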